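Saturating the allyl chain: from compound 2 to compound 3

The source may report more compounds than this note shows. Statements on the series, on what has been measured and on what is new or still open speak of the compounds shown alone.

Compound 1 `COc1cc(C(=O)NS(=O)(=O)c2ccccc2C)ccc1Cc1cn(C)c2ccc(C(=O)NCC3CCCC3)cc12`: 3.16 nM
Compound 2 `C=CCn1cc(Cc2ccc(C(=O)NS(=O)(=O)c3ccccc3C)cc2OC)c2cc(C(=O)NCC3CCCC3)ccc21`: 0.398 nM

Both compounds were tested in an assay on lung parenchyma for binding affinity to cysteinyl leukotriene receptor 1 (Cavia porcellus), read by radioligand binding; on this read-out lower numbers stand for stronger inhibition and higher numbers for weaker inhibition. Compound 2 gives the lower of the two numbers, with compound 1 the nearest neighbour; the step of a 7.9-fold lower number from compound 1 to compound 2 (0.90 log units; beyond the scatter) separates them. Compound 3 `CCCn1cc(Cc2ccc(C(=O)NS(=O)(=O)c3ccccc3C)cc2OC)c2cc(C(=O)NCC3CCCC3)ccc21` has not yet been measured. It differs from compound 2 by ethyl in place of vinyl on a saturated chain carbon bound to an aromatic nitrogen. Going by the values given here, the only measured step, a 7.9-fold lower number from compound 1 to compound 2 (0.90 log units; beyond the scatter), concerns adding the chain at that nitrogen, not whether the chain is saturated, so it gives no direct guide to the new change. Among the compounds with values here, with no step bearing on saturation itself, compound 3 is expected to stay close to compound 2, the estimated step of a 1.3-fold higher number from compound 2 to compound 3 (0.10 log units; within the scatter) lying within the scatter in this assay. Compound 3 is therefore estimated at 0.5 nM, with a range from 0.15 nM to 2 nM.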

Compound 3, inhibition constant: 0.316 nM
The estimate for compound 3 lay 1.6-fold (0.20 log units) above the measured number, within the range that was stated.
By their numbers in this assay, from the lowest: compounds 3 and 2 (each within the scatter of the next); then compound 1.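

In this assay, the double bond of the allyl chain makes no difference that can be told from scatter at this position: replacing vinyl with ethyl, which turns allyl into propyl, gives only a small step (a 1.3-fold lower number from compound 2 to compound 3 (0.10 log units; within the scatter)). The larger chain keeps its advantage over the methyl group of compound 1 when it is saturated (a 10-fold lower number from compound 1 to compound 3 (1.00 log units; beyond the scatter)), so that advantage does not depend on the double bond. Nothing measured here explains why the chain length matters or why saturation does not.

The compounds shown stop at the propyl and allyl chains, so a longer chain such as butyl could extend the gain, hold it or lose it. A chain ending in an amine or a carboxylic acid also remains an open question at this nitrogen.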